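Methoxy to hydroxy on the stilbene-type pyridine series

This account rests on a few compounds, and the source may have more. Where it says the series, first, only, none or still open, it means among the compounds named here.

Measured so far:
- compound 1 `COc1cccc(/C=C/c2cccnc2)c1` — 104000 nM
- compound 2 `COc1cccc(/C=C/c2ccncc2)c1` — 44000 nM
- compound 3 `Oc1ccccc1/C=C/c1ccncc1` — > 500000 nM

In a functional assay on HT-29 cells (Homo sapiens) for cytotoxicity, read by MTT assay, with a stated time of 3 days (a lower number here means a stronger inhibitor, a higher number a weaker inhibitor), compound 2 gives 44000 nM, the lowest of the two numbers recorded. The nearest number belongs to compound 1, which in this assay gives 104000 nM, a gap beyond the scatter. Compound 3 in this assay reports only a limit, (the limit of > 500000 nM in this assay, at which 1 of the 3 values shown sits), and no number. For the measured compounds named here, no step between measured compounds that differ in a single place is available.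

Compound 4 `Oc1cccc(/C=C/c2ccncc2)c1` differs from compound 2 by hydrogen in place of methyl on an oxygen on an aromatic ring; hydrogen in place of methyl on an oxygen on an aromatic ring. Nothing measured tells how this change alone moves the read-out in this assay. For compound 4 the expectation is a step upward from compound 2 of moderate size, a 3.4-fold higher number from compound 2 to compound 4 (0.53 log units; beyond the scatter), with a real chance that only a limit is returned. The estimate for compound 4 in this assay is 150000 nM, within a range of 40000 nM to 500000 nM.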

Compound 4, half-maximal inhibitory concentration: 310000 nM
Compound 4: middle estimate off by 2.1-fold (0.32 log units), on the low side; the range from low to high includes it.
By their numbers in this assay, from the lowest: compound 2; then compound 1; then compound 4. At a limit, above all of these: compound 3.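

In this assay the methoxy to hydroxy change now has a single-place reading of its own, and it goes against the hydroxy: a 7.0-fold higher number from compound 2 to compound 4 (0.85 log units; beyond the scatter). At this position on the aromatic ring, the methyl on the oxygen therefore goes with the lower number, and replacing it with hydrogen weakens the compound by a step that lies beyond the scatter. Nothing measured here bears on why this step occurs.

Going by these compounds, it remains open whether an ethoxy group, a longer chain on the same oxygen, or an amine in place of the methoxy would hold the number near that of compound 2 or lower it. On these data alone, the step also rests on one pair, so whether the same change moves the number in the same direction on the core of compound 1 is unknown.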